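The source may hold more compounds than are shown below. What is called first, only, known or untested is meant among the compounds shown, and "the series" means these compounds.

Three close relatives of one shared core have been tested in an assay on HeLa cells for displacement of a labelled ligand from 5-hydroxytryptamine receptor 6 (Homo sapiens); a lower number here means a stronger inhibitor, a higher number a weaker inhibitor. Compound 1 `CN1CCC(c2n[nH]c3ccc(S(=O)(=O)c4ccc5ccccc5c4)cc23)CC1` gives 9.6 nM, compound 2 `CN1CCC(c2n[nH]c3ccc(S(=O)(=O)c4cccc(Cl)c4)cc23)CC1` gives 19 nM, and compound 3 `CN1CCC(c2n[nH]c3ccc(S(=O)(=O)c4ccccc4)cc23)CC1` gives 55 nM. Compound 3 therefore has the highest number of the three: compound 2 lies a modest step lower, and compound 1 lies further below, both beyond the scatter.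

The next compound, compound 4 `CN1CCC(c2n[nH]c3ccc(S(=O)(=O)c4ccc(OC(F)(F)F)cc4)cc23)CC1`, differs from compound 3 in one place: trifluoromethoxy in place of hydrogen on an aromatic carbon.

Going by the values given here, only one measured step bears on this change. It is a 2.9-fold higher number from compound 2 to compound 3 (0.46 log units; beyond the scatter), where a chloro group on the same aromatic ring is removed. Compound 1 shows, without a single listed step, that a larger aromatic group at this position also goes with a lower number. Among the compounds with values here, both observations point the same way: a substituent on this ring lowers the number, so a modest drop beyond the scatter is expected here, though the new group sits at a different carbon and no step tells how much that matters.

The estimated result for compound 4 is 25 nM, with a range from 8 nM to 80 nM. That amounts to an expected 2.2-fold lower number from compound 3 to compound 4 (0.34 log units; beyond the scatter).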

Compound 4, inhibition constant: 48 nM
The estimate for compound 4 lay 1.9-fold (0.28 log units) below the measured number; measured number inside the range.
By their numbers in this assay, from the lowest: compounds 1 and 2 (each within the scatter of the next); then compounds 4 and 3 (each within the scatter of the next).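

In this assay, putting trifluoromethoxy on an aromatic carbon, para to a large group, gives a 1.1-fold lower number from compound 3 to compound 4 (0.06 log units; within the scatter), so this change leaves the number where it was. A substituent on this ring therefore does not always go with a lower number: compound 4 goes against the hint from the chloro group of compound 2, whose removal gives a 2.9-fold higher number from compound 2 to compound 3 (0.46 log units; beyond the scatter). No measurement shown here explains why these two changes differ.

The compounds shown leave open whether the difference comes from the group itself or from where it sits, since the chloro and trifluoromethoxy steps differ in more than one respect. On these data alone, a chloro group on the same carbon as the trifluoromethoxy would separate the two, and what an amine or a carboxylic acid would do there remains unknown.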